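The source may report more compounds than this note shows. Statements on the series, on what has been measured and on what is new or still open speak of the compounds shown alone.

Measured so far in a functional assay on NCI-H460 cells (Homo sapiens) for cytotoxicity, read by MTT assay, with a stated time of 68 h; a lower number here means a stronger inhibitor, a higher number a weaker inhibitor:

Compound 1 `CCOc1ccccc1-c1cc(NC(=O)C(Cl)Cl)cc(-c2ccccc2OCC)c1`: 5090 nM
Compound 2 `O=C(Nc1cccc(-c2cccs2)c1)C(Cl)Cl`: > 50000 nM, a limit of the assay
Compound 3 `Cc1ccc(-c2cccc(NC(=O)C(Cl)Cl)c2)cc1`: 8000 nM

Compound 3 gives 8000 nM and stands close to compound 1 at 5090 nM, the two lying within the scatter of each other. Compound 4 `O=C(Nc1cccc(-c2ccccc2)c1)C(Cl)Cl` has not yet been measured. It differs from compound 3 in having hydrogen in place of methyl on an aromatic carbon of a six-membered aromatic ring of carbon only, para to a large group: hydrogen in place of methyl on an aromatic carbon. Going by the values given here, no pair of measured compounds isolates this change, so its size in this assay can only be estimated. Compound 2, which has no methyl, gives only a limit, > 50000 nM, and that tilts the expectation towards a weaker number. A modest step in that direction is expected, not much beyond the scatter. The estimated step is a 1.8-fold higher number from compound 3 to compound 4 (0.24 log units; within the scatter). Compound 4 is expected at 14000 nM, with an estimated range from 5000 nM to 45000 nM.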

Compound 4, half-maximal inhibitory concentration: 20200 nM
The estimate for compound 4 lay 1.4-fold (0.16 log units) below the measured number; the measured number falls inside the stated range.
By their numbers in this assay, from the lowest: compounds 1 and 3 (each within the scatter of the next); then compound 4. At a limit, above all of these: compound 2.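

In this assay, the methyl group on this aromatic carbon, para to a large group, now has a measured effect: hydrogen in its place gives a 2.5-fold higher number from compound 3 to compound 4 (0.40 log units; beyond the scatter). The ring at the same place also counts, with phenyl in place of thiophen-2-yl giving an at least 2.4-fold lower number from compound 2 to compound 4 (0.39 log units; beyond the scatter). That second step is only a bound, because compound 2 stands at a limit of the assay: the limit of > 50000 nM in this assay, at which 1 of the 4 values shown sits.

The compounds shown compare only methyl and hydrogen on this carbon, so it remains open how a methoxy group, a chlorine atom, an amine or a longer chain would read there. On these data alone, compound 1 differs from compound 4 in more than one place, so what its ethoxy groups contribute also stays open.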